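The source may report more compounds than this note shows. Statements on the series, on what has been measured and on what is new or still open speak of the compounds shown alone.

In a functional assay on HL-60 cells (Homo sapiens) for cytotoxicity, read by CellTiter-Blue, with a stated time of 48 h (on this read-out higher numbers stand for weaker inhibition and lower numbers for stronger inhibition), the measured compounds read as follows:
Compound 1 `CC(C)(C)c1ccc(NC(=S)N/N=C2\C(=O)Nc3ccccc32)cc1` gives 6800 nM
Compound 2 `CCOC(=O)CC1C(C(=O)OCC)=C(N)Oc2ccc(-c3cccc(F)c3)cc21` gives 76400 nM
Compound 3 `CCOC(=O)CC1C(C(=O)OCC)=C(N)Oc2ccc(-c3ccc(F)cc3F)cc21` gives 76600 nM

Compound 3 stands with compound 2 at the high, weak-inhibition end of these numbers, while compound 1 has a clearly lower number, beyond the scatter. Compound 4 `CCOC(=O)CC1C(C(=O)OCC)=C(N)Oc2ccc(-c3ccccn3)cc21` carries pyridin-2-yl in place of 2,4-difluorophenyl on an aromatic carbon. Among the compounds with values here, one measured step bears on this change (a 1.0-fold higher number from compound 2 to compound 3 (0.00 log units; within the scatter)) and it lies within the scatter. On these data alone, that step swaps one carbon-only ring for another, so a ring with a hetero atom remains untested. No step beyond the scatter is therefore expected in this assay, and the estimate means a 1.1-fold lower number from compound 3 to compound 4 (0.04 log units; within the scatter) as the expected change. For compound 4 the estimated value is 70000 nM with 35000 nM to 130000 nM as its expected range.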

Compound 4, half-maximal inhibitory concentration: 76900 nM
Estimate against measurement, compound 4: 1.1-fold (0.04 log units) below; the range from low to high includes it.
By their numbers in this assay, from the lowest: compound 1; then compounds 2, 3 and 4 (each within the scatter of the next).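

In this assay pyridin-2-yl reads like the two fluorinated rings at this aromatic carbon: against 2,4-difluorophenyl the step is a 1.0-fold higher number from compound 3 to compound 4 (0.00 log units; within the scatter) and against 3-fluorophenyl it is a 1.0-fold higher number from compound 2 to compound 4 (0.00 log units; within the scatter). The earlier step compared only carbon-only rings, whereas these two steps show that, for these compounds, a ring nitrogen also leaves the number within the scatter. Nothing available explains why these numbers sit so close together.

Still open, on these data alone, is whether a group other than a six-membered aromatic ring, such as an amine or a carboxylic acid, would read differently at this carbon.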